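Triazole in Place of the Aminobenzyloxy Group

This account rests on a few compounds, and the source may have more. Where it says the series, first, only, none or still open, it means among the compounds named here.

In a functional assay on SK-OV-3 cells (Homo sapiens) for inhibition, read by CCK-8 assay, with a stated time of 70 h (on this read-out lower numbers stand for stronger inhibition and higher numbers for weaker inhibition), compound 1 (`Nc1ccc(COc2ccc(OCCOCCNC3CCCC3)cc2)cc1`) gives 31700 nM, compound 2 (`c1ccc(COc2ccc(COc3ccc(OCCOCCNC4CCCC4)cc3)cc2)cc1`) gives 10000 nM and compound 3 (`O=[N+]([O-])c1ccc(COc2ccc(OCCOCCNC3CCCC3)cc2)cc1`) gives 20300 nM. Compound 1 thus stands at the high-number end of these three, level with compound 3 within the scatter, as the measured change shows: a 1.6-fold lower number from compound 1 to compound 3 (0.19 log units; within the scatter). Only compound 2 stands clearly apart from it, with a 3.2-fold lower number from compound 1 to compound 2 (0.50 log units; beyond the scatter). The remaining comparison is a 2.0-fold higher number from compound 2 to compound 3 (0.31 log units; beyond the scatter).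

Compound 4 (`c1ncn(-c2ccc(OCCOCCNC3CCCC3)cc2)n1`) carries 1H-1,2,4-triazol-1-yl in place of (4-aminobenzyl)oxy on an aromatic carbon, para to a large group: 1H-1,2,4-triazol-1-yl in place of (4-aminobenzyl)oxy on an aromatic carbon. This change goes further than any measured so far. Among the compounds with values here, the steps from compound 1 replace only the amino group, whereas here the whole (4-aminobenzyl)oxy group leaves, and no measured compound carries a triazole. These steps therefore bear on it only loosely, but none of them exceeds a modest size. With no evidence for a direction, the expected step in this assay is a 1.1-fold lower number from compound 1 to compound 4 (0.05 log units; within the scatter), which is nothing beyond the scatter. For compound 4 the estimated value is 28000 nM, with an expected range from 12000 nM to 65000 nM.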

Compound 4, half-maximal inhibitory concentration: > 100000 nM
Compound 4: no number, only a limit (the forecaster's own chance of this, stated with the estimate: 20%); middle value at least 3.5-fold (0.55 log units) from the limit.
By their numbers in this assay, from the lowest: compound 2; then compounds 3 and 1 (each within the scatter of the next). At a limit, above all of these: compound 4.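

In this assay compound 4 gives > 100000 nM, which is a limit of the assay and not a number. Replacing the whole (4-aminobenzyl)oxy group with 1H-1,2,4-triazol-1-yl gives the first step from compound 1 toward a higher number, an at least 3.1-fold higher number from compound 1 to compound 4 (0.49 log units; beyond the scatter), so this place on the aromatic ring, para to a large group, is shown for the first time to be sensitive to the change in this direction, whereas the earlier compounds, each of which keeps a benzyl unit there, showed only steps of modest size or steps within the scatter. The true size of the step stays unknown, and only its lower bound can be read: the limit of > 100000 nM in this assay, at which 1 of the 4 values shown sits.

The compounds shown leave open whether the higher number comes from the triazole itself or from the loss of the six-membered aromatic ring and the oxygen, since this single change removes both, and a 1H-1,2,4-triazol-1-ylmethoxy group or a plain benzyloxy group at this place would separate the two. On these data alone, how an amine or a carboxylic acid on a longer chain would behave at this place also remains open.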